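A few compounds are considered here, and "the series" means these few. Any claim that something is new, unique, unknown or untested is made for them only; others in the source may bear on it.

Among the measured compounds shown here, compound 1 `CNc1ncnc2c1ncn2C1O[C@H](CO)[C@@](C)(O)[C@H]1O` is the only member of this small set to return a number in a functional assay on K562 cells (Homo sapiens) for inhibition; a lower number here means a stronger inhibitor, a higher number a weaker inhibitor: there compound 1 gives 93800 nM. Compound 2 `C[C@]1(O)C(n2cnc3c(NC4CC4)ncnc32)O[C@H](CO)[C@H]1O` in this assay gives only a limit, > 100000 nM, so that the limit of > 100000 nM in this assay, at which 1 of the 2 values shown sits, applies to it. Compound 3 `C[C@@]1(O)[C@@H](CO)OC(n2cnc3c(NC4CC4)ncnc32)[C@@H]1O` has not yet been measured. It differs from compound 1 in one place: cyclopropyl in place of methyl on a nitrogen on an aromatic ring. For the measured compounds named here, no measured pair shows this single change, so the size of the step in this assay cannot be read from the data at hand. Compound 1 sits close to the weak end of this assay, and compound 2, which also carries the cyclopropylamino group, stopped at the limit. The estimate for compound 3 is accordingly a weaker value of 150000 nM with a range from 50000 nM to 500000 nM, meaning an expected step of a 1.6-fold higher number from compound 1 to compound 3 (0.20 log units; within the scatter) that may well end at the limit once more.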

Compound 3, half-maximal inhibitory concentration: > 100000 nM
Compound 3 ended at the assay's limit (the forecaster's own chance of this, stated with the estimate: 60%); the middle value does not contradict the limit.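

In this assay compound 3 gives > 100000 nM, which is a limit and not a number. The change from methylamino to cyclopropylamino on a nitrogen on an aromatic ring can therefore be read only as a floor, an at least 1.0-fold higher number from compound 1 to compound 3 (0.02 log units; that floor lies within the scatter), and this gives the first view of the change, though not its true size. Cyclopropyl in place of methyl at this nitrogen brings no measurable gain in inhibition, and the result joins the ceiling of the read-out: the limit of > 100000 nM in this assay, at which 2 of the 3 values shown sit.

The compounds shown leave open how far beyond the limit compound 3 lies, so it remains unclear whether the step is real or lies within the scatter. They also leave open whether a different group on this nitrogen, such as an unsubstituted amine or a benzyl group, would give a lower number.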